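Working notes: hydrogen in place of cyano

The source may report more compounds than this note shows. Statements on the series, on what has been measured and on what is new or still open speak of the compounds shown alone.

Measured so far in an ADME assay on MT4 cells (Homo sapiens) for cytotoxicity, read by MTT assay, with a stated time of 5 days; on this read-out lower numbers stand for higher toxicity in this test and higher numbers for lower toxicity in this test:
- compound 1 `Cc1cccc(C)c1Oc1cc(Nc2ccc(C#N)cc2)[nH]c(=O)c1Br` gives 63000 nM
- compound 2 `Cc1cc(C)c(Oc2cc(Nc3ccc(C#N)cc3)[nH]c(=O)c2)c(C)c1` gives 32000 nM
- compound 3 `Cc1cc(C#N)cc(C)c1Oc1cc(Nc2ccc(C#N)cc2)[nH]c(=O)c1` gives 25000 nM

Compound 3 stands within the scatter of compound 2 but clearly apart from compound 1, which holds the higher value of that pair, and that gap lies beyond the scatter. The next compound is compound 4 `Cc1cccc(C)c1Oc1cc(Nc2ccc(C#N)cc2)[nH]c(=O)c1`, which carries hydrogen in place of cyano on an aromatic carbon, meta to two methyl groups (hydrogen in place of cyano on an aromatic carbon). Among the measured compounds shown here, the one measured step at that carbon is cyano in place of methyl, and it gave a 1.3-fold lower number from compound 2 to compound 3 (0.11 log units; within the scatter) in this assay as its result. This is a single step, and it does not involve hydrogen. Compound 1 (63000 nM) also has hydrogen at that carbon but differs from compound 4 on the core, so it offers only a weak lean towards higher numbers. No step beyond the scatter is expected, and the expected change is a 1.3-fold higher number from compound 3 to compound 4 (0.11 log units; within the scatter) at most a small rise. For compound 4 the estimated value is 32000 nM (expected range 14000 nM to 75000 nM).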

Compound 4, half-maximal cytotoxic concentration: 36000 nM
Compound 4: middle estimate off by 1.1-fold (0.05 log units), on the low side, and the stated range covers the measured number.
By their numbers in this assay, from the lowest: compounds 3, 2, 4 and 1 (each within the scatter of the next, the first and the last beyond it).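

At the aromatic carbon meta to two methyl groups, hydrogen now stands alongside cyano and methyl in this assay, and neither exchange leaves the scatter (a 1.4-fold higher number from compound 3 to compound 4 (0.16 log units; within the scatter); a 1.1-fold higher number from compound 2 to compound 4 (0.05 log units; within the scatter)). For these three groups, then, this assay draws no clear distinction at this carbon, and the earlier single step between cyano and methyl now extends to a set of three compounds with hydrogen as the common reference. Compound 4 also links compound 1 to the others through one change on the shared core, where bromo gives way to hydrogen, and this step too stays within the scatter (a 1.8-fold lower number from compound 1 to compound 4 (0.24 log units; within the scatter)), even though compound 1 and compound 3 stand beyond the scatter of each other.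

No available measurement bears on the reason these groups read alike in this test. Still open, as far as these compounds go, is whether an amine, a carboxylic acid or a longer chain at the carbon meta to two methyl groups would give a number beyond the scatter, and whether the bromo exchange would read the same in a compound carrying cyano at that carbon.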